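The source may hold more compounds than are shown below. What is called first, only, known or untested is meant among the compounds shown, and "the series" means these compounds.

Of the compounds shown here, three on a shared core have been measured in a functional assay on ACHN cells (Homo sapiens) for inhibition, read by sulforhodamine B assay, with a stated time of 48 h; a higher number here means that more compound is tolerated, a lower number that less compound is tolerated. Compound 1 `COc1ccc(CNc2nc3cc(N)cc(N)c3nc2-c2ccccc2)cc1OC` gives 81300 nM and compound 3 `COc1ccc(CNc2nc3cc(N)cc(N)c3nc2-c2ccccc2)cc1` gives 75900 nM, while compound 2 `Nc1cc(N)c2nc(-c3ccccc3)c(NCc3ccc(F)cc3)nc2c1` gives 5620 nM, the lowest of the three numbers. The steps are a 14-fold lower number from compound 1 to compound 2 (1.16 log units; beyond the scatter), a 14-fold higher number from compound 2 to compound 3 (1.13 log units; beyond the scatter) and a 1.1-fold lower number from compound 1 to compound 3 (0.03 log units; within the scatter). Compound 4 `Nc1cc(N)c2nc(-c3ccccc3)c(Oc3ccc(F)cc3)nc2c1` carries 4-fluorophenoxy in place of (4-fluorobenzyl)amino on an aromatic carbon. Within the data shown here, no measured step changes the link between the core and the fluorine-bearing ring, so the measured steps offer no direct guide; the fluorine is kept, and compound 2 with that fluorine gives 5620 nM. A moderate rise, a 2.7-fold higher number from compound 2 to compound 4 (0.43 log units; beyond the scatter), is expected, with wide uncertainty. Compound 4 is therefore estimated at 15000 nM, within 3000 nM to 80000 nM.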

Compound 4, concentration lethal to 50% of the cells: 81300 nM
Compound 4: middle estimate off by 5.4-fold (0.73 log units), on the low side; measured number above the stated range.
By their numbers in this assay, from the lowest: compound 2; then compounds 3, 1 and 4 (each within the scatter of the next).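

In this assay, 4-fluorophenoxy in place of (4-fluorobenzyl)amino gives a 14-fold higher number from compound 2 to compound 4 (1.16 log units; beyond the scatter) at this aromatic carbon next to the ring nitrogen. The earlier steps shown here changed only substituents on the outer ring, whereas this one keeps the fluorine and changes the link, showing that the link alone can carry a large step. Nothing measured here explains that step.

The change swaps the nitrogen for oxygen, loses the hydrogen-bond donor and shortens the link, so these remain unseparated. A 4-fluoroanilino group, which keeps the nitrogen without the chain carbon, and a 4-fluorobenzyloxy group, which keeps the chain carbon with oxygen, would pull them apart.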